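The source may report more compounds than this note shows. Statements on the series, on what has been measured and on what is new or still open speak of the compounds shown alone.

Measured compounds, cytotoxicity read-out:

compound 1 `OB1OCc2ccc(-n3cc(Sc4ccc(Cl)c(Cl)c4)c4ccccc43)cc21`: > 10 ug/mL
compound 2 `OB1OCc2ccc(-n3cccc3)cc21`: > 10 ug/mL
compound 3 `OB1OCc2ccc(-n3cccc3Sc3ccc(Cl)cc3)cc21`: > 10 ug/mL

All three were run in an ADME assay on L929 cells (Mus musculus) for cytotoxicity, read by resazurin assay, with a stated time of 72 h; a lower number here means a stronger inhibitor, a higher number a weaker inhibitor. For compound 1 the entry > 10 ug/mL is a limit of the assay, not a number. For compound 3 the entry > 10 ug/mL is likewise a limit. Going by the values given here, compound 2 stands at the limit > 10 ug/mL, which is where every value sits (the limit of > 10 ug/mL in this assay, at which 3 of the 3 values shown sit); no compound in the set gives a measured number, so there is no spread to rank compound 2 within.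

Compound 4 `O=C(O)c1cccn1-c1ccc2c(c1)B(O)OC2` is the next member to be measured. It differs from compound 2 by carboxy in place of hydrogen on an aromatic carbon. Among the compounds with values here, no step between measured compounds exists to calibrate this change. The expectation is that the step from compound 2 to compound 4 in this assay is none beyond the scatter, with compound 4 most likely again reported as a limit. For compound 4 the estimate is 20 ug/mL, with a range from 8 ug/mL to 60 ug/mL, which would mean an expected step that the limit leaves unreadable from compound 2 to compound 4.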

Compound 4, half-maximal inhibitory concentration: > 10 ug/mL
Compound 4: a limit, no number; the forecaster's own chance of this, stated with the estimate: 85%; the middle value is on the limit's open side.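

In this assay compound 4 gives > 10 ug/mL as a limit, not a number. Going by these compounds alone, no step from compound 2 to compound 4 can be read: the limit of > 10 ug/mL in this assay, at which 4 of the 4 values shown sit. The compounds shown leave open how far carboxy in place of hydrogen on an aromatic carbon shifts cytotoxicity, and whether any compound here reaches a measurable value in this assay.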